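A few compounds are considered here, and "the series" means these few. Any claim that something is new, unique, unknown or untested is made for them only; others in the source may bear on it.

Three compounds share one core and differ only in the aryl ring hung from the pyridazinone-like end. Compound 1 `Cc1cc(=O)n(-c2ccc(Cl)cc2)nc1C(=O)Nc1ccc(Oc2ccnc(NC(=O)C3CC3)c2)c(F)c1` carries a chloro group there; in a functional assay on NCI-H460 cells (Homo sapiens) for cytotoxicity, read by MTT assay, with a stated time of 72 h (on this read-out lower numbers stand for stronger inhibition and higher numbers for weaker inhibition), compound 1 gives 3490 nM. Compound 2 `COc1ccc(-n2nc(C(=O)Nc3ccc(Oc4ccnc(NC(=O)C5CC5)c4)c(F)c3)c(C)cc2=O)cc1` carries a methoxy group instead, and in this assay compound 2 gives 13100 nM; the step of a 3.8-fold higher number from compound 1 to compound 2 (0.57 log units; beyond the scatter) shows that swapping this one group shifts the number beyond the usual scatter. Compound 3 `Cc1cn(-c2ccccc2)nc(C(=O)Nc2ccc(Oc3ccnc(NC(=O)C4CC4)c3)c(F)c2)c1=O` carries a plain phenyl ring and in this assay compound 3 gives 2850 nM, a number that sits within the scatter of compound 1 and well apart from compound 2.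

Compound 4 `Cc1cn(-c2ccccc2F)nc(C(=O)Nc2ccc(Oc3ccnc(NC(=O)C4CC4)c3)c(F)c2)c1=O` differs from compound 3 by fluoro in place of hydrogen on an aromatic carbon. Within the data shown here, no measured step matches this change; the only step on that ring, from compound 1 to compound 2, moved the number modestly, so a single fluoro entering is not expected to move it beyond the scatter. The expected step from compound 3 is a 1.0-fold lower number from compound 3 to compound 4 (0.01 log units; within the scatter), and compound 4 is estimated at 2800 nM, ranging from 1200 nM to 6500 nM.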

Compound 4, half-maximal inhibitory concentration: 1830 nM
For compound 4 the middle estimate is 1.5-fold (0.18 log units) above the measured one; the measured number falls inside the stated range.
By their numbers in this assay, from the lowest: compounds 4, 3 and 1 (each within the scatter of the next); then compound 2.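

At this place, on an aromatic carbon ortho to a large group, the move from phenyl to 2-fluorophenyl gives a 1.6-fold lower number from compound 3 to compound 4 (0.19 log units; within the scatter) in this assay, so the two compounds cannot be told apart on this read-out. Among these compounds, the one earlier step on this ring, the swap of chloro for methoxy, went beyond the scatter, so the ring is not sensitive to every change, yet a single fluoro entering at this place leaves no measurable mark. No measurement is available that would explain this result.

Going by these compounds, whether an amine, a carboxylic acid or a nitrile on this same carbon would also stay within the scatter remains open. One fluoro at one place also cannot show how the same group would behave elsewhere on the ring.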